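The compounds below may be only part of what the source reports. "The series", "measured", "known", "first", "only" and "open" are said of these compounds alone.

Compounds measured in an assay on cells for activation of Cystic fibrosis transmembrane conductance regulator (Homo sapiens), read by fluorescence, with a stated time of 10 min; a lower number here means that less compound is needed, a higher number that more compound is needed for the effect:
compound 1 `O=C(O)c1ccc([N+](=O)[O-])c(-c2nc3ccccc3n(Cc3ccccc3)c2=O)c1`, reported only as a limit, > 10000 nM
compound 2 `O=c1c(-c2ccc(C(F)(F)F)cc2)nc2ccccc2n1Cc1ccccc1`, 1000 nM
compound 3 `CCn1c(=O)c(-c2cccc([N+](=O)[O-])c2)nc2ccccc21`, 65 nM

Among the two numbers in this assay, compound 3 stands lowest; compound 2 gives 1000 nM, a higher number that lies beyond the scatter. The value of compound 1 is a limit of the assay and not a number (the limit of > 10000 nM in this assay, at which 1 of the 3 values shown sits).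

Compound 4 `O=c1c(-c2cccc([N+](=O)[O-])c2)nc2ccccc2n1Cc1ccccn1` differs from compound 3 in one place: pyridin-2-yl in place of methyl on a saturated chain carbon bound to an aromatic nitrogen. For the measured compounds named here, no measured pair of compounds covers this change, so the size of its step is open. The expectation is a small step from compound 3 to compound 4 toward a somewhat higher number, possibly within the scatter, a 2.3-fold higher number from compound 3 to compound 4 (0.36 log units; beyond the scatter). For compound 4 the estimated value is 150 nM, with a range from 40 nM to 600 nM.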

Compound 4, half-maximal effective concentration: 52 nM
Estimate against measurement, compound 4: 2.9-fold (0.46 log units) above, and the stated range covers the measured number.
By their numbers in this assay, from the lowest: compounds 4 and 3 (each within the scatter of the next); then compound 2. At a limit, above all of these: compound 1.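

With the 3-nitrophenyl group and the rest of the core unchanged, the replacement of methyl by pyridin-2-yl on a saturated chain carbon bound to an aromatic nitrogen gives a 1.3-fold lower number from compound 3 to compound 4 (0.10 log units; within the scatter) in this assay. For the compounds shown here, this is the first pair to differ at this place alone, and it shows that this place can carry a six-membered aromatic ring with no step beyond the scatter. Nothing available here explains this result.

The compounds shown leave open how phenyl, an amine or a longer chain such as propyl would read at this place. On these data alone, whether the ring nitrogen of pyridin-2-yl matters also stays open.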